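Swapping the sulfonyl aryl ring in a quinoline series

The source may hold more compounds than are shown below. What is called first, only, known or untested is meant among the compounds shown, and "the series" means these compounds.

Compound 1 `COCC1CCN(c2c(S(=O)(=O)c3cc(F)cc(F)c3)cnc3cc(F)ccc23)CC1`: 83%
Compound 2 `NS(=O)(=O)N1CCN(c2c(S(=O)(=O)c3cc(F)cc(F)c3)cnc3cc(F)ccc23)CC1`: 6.4%
Compound 3 `COc1ccc2ncc(S(=O)(=O)c3ccc(F)cc3)c(N3CCC(C)CC3)c2c1`: 27%

In an assay on isolated protein for displacement of a labelled ligand from metabotropic glutamate receptor 5 (Homo sapiens), with a stated time of 60 min, tested at 1 uM (a higher number here means more inhibition at the concentration tested (going by the name of the read-out), a lower number less inhibition), compound 1 stands highest of the three measured compounds. Compound 3 sits well below it, and compound 2 lies furthest away: a number 76.6 percentage points lower from compound 1 to compound 2 (beyond the scatter). Compound 3 differs from compound 1 in more than one place, so only its value is known, not a single step.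

Compound 4 `COCC1CCN(c2c(S(=O)(=O)c3cccc(C#N)c3)cnc3cc(F)ccc23)CC1` follows from compound 1 by one change: 3-cyanophenyl in place of 3,5-difluorophenyl on a sulfonyl sulfur. Going by the values given here, no measured step touches this sulfonyl aryl group, so the only direct guide is the value of compound 1. The step is therefore expected to be small, most likely a modest loss within or somewhat beyond the scatter: a number 18 percentage points lower from compound 1 to compound 4 (beyond the scatter). Compound 4 is estimated at 65%, in the range 35% to 90%.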

Compound 4, a percentage reported as inhibition, at one concentration (the size of the read-out at that concentration, not a potency): 91%
Estimate against measurement, compound 4: 26 percentage points below, and the stated range ends below it.
By their numbers in this assay, from the lowest: compound 2; then compound 3; then compounds 1 and 4 (each within the scatter of the next).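

The change of 3,5-difluorophenyl to 3-cyanophenyl on the sulfonyl sulfur gives a number 8 percentage points higher from compound 1 to compound 4 (within the scatter) in this assay and so shows that this position can change without a measurable shift in the read-out. With the 4-(methoxymethyl)piperidin-1-yl group and the shared core held fixed, the two fluorines can give way to a single nitrile. From the compounds shown here alone, whether a pyridine ring, an unsubstituted phenyl or a longer chain would also hold the value at this position stays open. Nothing measured here explains why the two aryl groups read alike.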